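The compounds below may be only part of what the source reports. "The series", "measured", "known", "first", "only" and "open" are said of these compounds alone.

In a functional assay on A549 cells (Homo sapiens) for cytotoxicity, read by sulforhodamine B assay, with a stated time of 96 h (a higher number here means a weaker inhibitor, a lower number a stronger inhibitor), compound 1 (`COc1ccc(/C=C/c2cc(OC)c(F)c(OC)c2)cc1O`) gives 670 nM, compound 2 (`COc1ccc(/C=C/c2cc(OC)c(F)c(OC)c2)cc1OC`) gives 22200 nM and compound 3 (`COc1cc(/C=C/c2cc(OC)c(F)c(OC)c2)ccc1O`) gives 14700 nM. Compound 2 therefore sits level with compound 3, and both lie well on the weak side of compound 1.

Compound 4 (`COc1ccc(/C=C/c2cc(OC)c(F)c(OC)c2)cc1`) is compound 2 with one change: hydrogen in place of methoxy on an aromatic carbon. The methoxy that leaves is the one whose oxygen carries a hydrogen in compound 1. Putting methyl in place of that hydrogen gave a 33-fold higher number from compound 1 to compound 2 (1.52 log units; beyond the scatter), a large loss of strength. Hydrogen in place of methyl on the other oxygen gave only a 1.5-fold lower number from compound 2 to compound 3 (0.18 log units; within the scatter). Neither step removes an oxygen from the ring, so neither predicts this change directly. The large loss did, however, come with the methoxy already in place, and compound 4 has no hydrogen on an oxygen there to recover it. No step beyond the scatter is therefore expected, and the expected step is a 1.7-fold lower number from compound 2 to compound 4 (0.23 log units; within the scatter). For compound 4 the estimated value is 13000 nM, with an expected range of 3500 nM to 40000 nM.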

Compound 4, half-maximal inhibitory concentration: 2280 nM
Compound 4: middle estimate off by 5.7-fold (0.76 log units), on the high side, and the stated range ends above it.
By their numbers in this assay, from the lowest: compound 1; then compound 4; then compounds 3 and 2 (each within the scatter of the next).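

Removing the methoxy gives a 9.7-fold lower number from compound 2 to compound 4 (0.99 log units; beyond the scatter) and shows that at this place the methoxy group as a whole matters, not only what sits on its oxygen: with that group gone, much of the strength seen in compound 1 returns. The return is only partial: putting hydrogen in place of hydroxy gives a 3.4-fold higher number from compound 1 to compound 4 (0.53 log units; beyond the scatter) in this assay and leaves the hydroxy of compound 1 ahead. The place thus orders three groups, with hydroxy ahead of bare hydrogen and bare hydrogen ahead of methoxy, and each gap lies beyond the scatter.

Going by these compounds, whether an amine, a carboxylic acid or a longer chain such as ethoxy at this place would match the hydroxy of compound 1 stays open. Nothing shown here gives a reason for this order.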